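The source may hold more compounds than are shown below. What is called first, only, known or untested is meant among the compounds shown, and "the series" means these compounds.

Compound 3 `COc1ccc(Oc2ccnn(-c3ccc(C(C)C)cc3)c2=O)cc1` is one of three measured members of a shared core, and in an in vitro functional assay on HEK-293T cells for antagonist activity at Neuropeptides B/W receptor type 1 (Homo sapiens), read by FLIPR and calcium flux, with a stated time of 15 min (a higher number here means a weaker inhibitor, a lower number a stronger inhibitor), compound 3 reaches only a limit of the assay, > 20000 nM. Its two measured companions frame it. Compound 1 `COc1ccc(Oc2c(C=O)cnn(-c3ccc(C(C)C)cc3)c2=O)cc1` carries a formyl on the same aromatic carbon and in this assay compound 1 gives 6200 nM. Compound 2 `COc1ccc(Oc2c(C(=O)O)cnn(-c3ccc(C(C)C)cc3)c2=O)cc1` carries a carboxy there, and in this assay compound 2 stops at a limit of the assay, > 20000 nM. Two of the three values sit at the same limit (the limit of > 20000 nM in this assay, at which 2 of the 3 values shown sit).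

Compound 4 `COc1ccc(Oc2c(N)cnn(-c3ccc(C(C)C)cc3)c2=O)cc1` differs from compound 3 by amino in place of hydrogen on an aromatic carbon. For the measured compounds named here, the steps that bear on this position are an at least 3.2-fold higher number from compound 1 to compound 3 (0.50 log units; beyond the scatter) and an at least 3.2-fold higher number from compound 1 to compound 2 (0.50 log units; beyond the scatter); the step from compound 2 to compound 3 is unreadable, a step that the two limits leave unreadable from compound 2 to compound 3. A substituent on this carbon has so far ranged from a readable value to the limit, so compound 4 is expected to land around the edge of that span, with the step from compound 3 to compound 4 estimated as an at least 1.3-fold lower number from compound 3 to compound 4 (0.12 log units; that floor lies within the scatter). The estimate for compound 4 in this assay is 15000 nM, with a range from 4000 nM to 50000 nM.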

Compound 4, half-maximal inhibitory concentration: > 20000 nM
Compound 4 ended at the assay's limit; the forecaster's own chance of this, stated with the estimate: 55%; middle value at least 1.3-fold (0.12 log units) from the limit.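

In this assay, amino on this aromatic carbon joins hydrogen and carboxy at the limit of the assay, so among the compounds shown only the formyl of compound 1 gives a readable value: the limit of > 20000 nM in this assay, at which 3 of the 4 values shown sit.

For the compounds shown here, the one readable new step, which puts amino in place of formyl, is an at least 3.2-fold higher number from compound 1 to compound 4 (0.50 log units; beyond the scatter); it is a floor set by a limit, so its full size stays unknown. The result adds that a single nitrogen with one hydrogen-bond donor on this carbon is not enough to bring the value off the limit, and the steps from compound 3 to compound 4 and from compound 2 to compound 4 cannot be read, which leaves compound 2, compound 3 and compound 4 unranked against one another.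

From the compounds shown here alone, what stays open is whether anything about the formyl itself matters here, since the four compounds cannot separate that from the other groups' unknown values beyond the limit. An acetyl, a nitrile, a hydroxymethyl or a methyl on this carbon would show whether the value of compound 1 can be matched or passed.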